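Thioether ring in place of the ether side chain

The source may report more compounds than this note shows. Statements on the series, on what has been measured and on what is new or still open speak of the compounds shown alone.

Among the measured compounds shown here, compound 2 `O=C(NCc1ccc(C(F)(F)F)nc1OCC1CCC1)Nc1cccc2c(=O)[nH]ccc12` gives 63.2 nM in an assay on CHO cells for agonist activity at transient receptor potential cation channel subfamily V member 1 (Homo sapiens) (on this read-out lower numbers stand for an effect already at smaller amounts and higher numbers for an effect only at larger amounts of compound), the higher of the two numbers known so far, while compound 1 `O=C(NCc1ccc(C(F)(F)F)nc1N1CCCCC1)Nc1cccc2c(=O)[nH]ccc12` gives 13.2 nM. For the measured compounds named here, the one measured step at this position is a 4.8-fold higher number from compound 1 to compound 2 (0.68 log units; beyond the scatter). Compound 3 `O=C(NCc1ccc(C(F)(F)F)nc1SC1CCCCC1)Nc1cccc2c(=O)[nH]ccc12` differs from compound 2 in cyclohexylsulfanyl in place of cyclobutylmethoxy on an aromatic carbon. That earlier step bears on the change only loosely, as the new group again carries a six-membered ring; a modest move toward a lower number is expected, a 1.8-fold lower number from compound 2 to compound 3 (0.26 log units; within the scatter). Compound 3 is therefore estimated at 35 nM, within 12 nM to 100 nM.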

Compound 3, half-maximal effective concentration: 69.3 nM
For compound 3 the middle estimate is 2.0-fold (0.30 log units) below the measured one, and the stated range covers the measured number.
By their numbers in this assay, from the lowest: compound 1; then compounds 2 and 3 (each within the scatter of the next).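

In this assay, the change at this aromatic carbon from cyclobutylmethoxy to cyclohexylsulfanyl leaves the number within the scatter (a 1.1-fold higher number from compound 2 to compound 3 (0.04 log units; within the scatter)), even though the attaching atom and the ring size both differ. Compound 3, like compound 2, stands beyond the scatter from compound 1 (a 5.3-fold higher number from compound 1 to compound 3 (0.72 log units; beyond the scatter)), so piperidin-1-yl remains the group with the lowest number here. No measurement available explains this result.

The compounds shown leave open how the attaching atom and ring size act separately, which a cyclohexyloxy group would help to resolve. They also leave open whether an open-chain amine such as diethylamino matches compound 1.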